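Nitro for Chloro on the Phenylpiperazine Arm

This account rests on a few compounds, and the source may have more. Where it says the series, first, only, none or still open, it means among the compounds named here.

Measured compounds:
compound 1 `O=C1Nc2cc(Br)ccc2/C1=N/NC(=S)N1CCN(c2ccccc2)CC1` with 19700 nM
compound 2 `O=C1Nc2ccc(Cl)cc2/C1=N/NC(=S)N1CCN(c2ccc(Cl)cc2)CC1` with 13100 nM

Two compounds share a core carrying a thiosemicarbazide link to a phenylpiperazine. In a functional assay on MCF7 cells (Homo sapiens) for inhibition, read by MTT assay, with a stated time of 72 h (on this read-out higher numbers stand for weaker inhibition and lower numbers for stronger inhibition), compound 1 gives 19700 nM. In this assay compound 2 gives 13100 nM, the lowest of the two numbers, though compound 1 stands so close that the two cannot be told apart within the usual scatter of such measurements.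

The step to compound 3 `O=C1Nc2ccc(Cl)cc2/C1=N/NC(=S)N1CCN(c2ccc([N+](=O)[O-])cc2)CC1` changes compound 2 in one place: nitro in place of chloro on an aromatic carbon on an aromatic carbon of a six-membered aromatic ring of carbon only, para to a large group. Within the data shown here, no pair of measured compounds shows what such an exchange does in this assay, so there is no measured step to lean on. With nothing else to go by, the expectation is that the step from compound 2 to compound 3 stays close to nothing beyond the scatter, in either direction.

On that basis compound 3 is estimated at 12000 nM in this assay, with a range from 4000 nM to 36000 nM, an expected step of a 1.1-fold lower number from compound 2 to compound 3 (0.04 log units; within the scatter).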

Compound 3, half-maximal inhibitory concentration: 20900 nM
Beside the measured number, compound 3's estimate is 1.7-fold (0.24 log units) below it, and the stated range covers the measured number.
By their numbers in this assay, from the lowest: compounds 2, 1 and 3 (each within the scatter of the next).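

In this assay, putting nitro in place of chloro on an aromatic carbon para to a large group gives a 1.6-fold higher number from compound 2 to compound 3 (0.20 log units; within the scatter) and so leaves compound 2 and compound 3 indistinguishable on this read-out. Among these compounds, this is the first measured single-place step, since compound 1 and compound 2 differ in more than one place, and it shows that a 4-nitrophenyl group, which carries hydrogen-bond acceptors that chloro lacks, reads no differently here from a 4-chlorophenyl group. No measurement offered here bears on why this exchange reads as it does.

The compounds shown leave open whether an amine or a carboxylic acid on this same aromatic carbon would give a step beyond the scatter in this assay. They also leave open whether nitro in place of chloro would read the same on a core carrying bromo, as compound 1 does, rather than the chloro shared by compound 2 and compound 3.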